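The source may hold more compounds than are shown below. What is called first, only, known or untested is meant among the compounds shown, and "the series" means these compounds.

Measured so far:
compound 1 `COC(=O)Cn1cc(Nc2ncnc3ccc(-c4cnc(OC)c(NS(=O)(=O)c5ccc(F)cc5F)c4)cc23)cn1`: 670 nM
compound 2 `COC(=O)CCn1cc(Nc2ncnc3ccc(-c4cnc(OC)c(NS(C)(=O)=O)c4)cc23)cn1`: 490 nM

In a functional assay on MCF7 cells (Homo sapiens) for antiproliferative activity, read by sulforhodamine B assay, with a stated time of 72 h (on this read-out higher numbers stand for weaker inhibition and lower numbers for stronger inhibition), compound 1 gives 670 nM, the higher of the two numbers in hand; compound 2 gives 490 nM, and the gap between them lies within the scatter, so no order between the two can be read. Compound 3 `COc1ncc(-c2ccc3ncnc(Nc4ccc(OCCO)nc4)c3c2)cc1NS(=O)(=O)c1ccc(F)cc1F` is not yet measured. It differs from compound 1 in one place: 6-(2-hydroxyethoxy)pyridin-3-yl in place of 1-((methoxycarbonyl)methyl)-1H-pyrazol-4-yl on a nitrogen on an aromatic ring. The group that leaves carries 0 hydrogen-bond donors and 4 hydrogen-bond acceptors; the group that enters carries 1 hydrogen-bond donor and 3 hydrogen-bond acceptors. Going by the values given here, no measured pair shows this change, so nothing is known here of its direction. The shared core and the sulfonamide side of compound 1 are kept unchanged. The step from compound 1 to compound 3 is expected to be small, within the scatter, and given as a 1.2-fold lower number from compound 1 to compound 3 (0.09 log units; within the scatter). For compound 3 the estimate in this assay is 550 nM, with a range from 150 nM to 2000 nM.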

Compound 3, half-maximal inhibitory concentration: 4300 nM
Beside the measured number, compound 3's estimate is 7.8-fold (0.89 log units) below it; measured number above the stated range.
By their numbers in this assay, from the lowest: compounds 2 and 1 (each within the scatter of the next); then compound 3.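

In this assay, going by these compounds alone, the group on a nitrogen on an aromatic ring matters to the read-out: 6-(2-hydroxyethoxy)pyridin-3-yl in place of 1-((methoxycarbonyl)methyl)-1H-pyrazol-4-yl gives a 6.4-fold higher number from compound 1 to compound 3 (0.81 log units; beyond the scatter), the only step in hand and one beyond the scatter. The shared core and the sulfonamide side stay unchanged, so this single change carries the whole step, and the two groups are not interchangeable here despite their equal heavy-atom count. Nothing measured on these compounds accounts for the step.

The ring and its side chain change together, so the compounds shown cannot tell which of the two carries the step. A 1H-pyrazol-4-yl group bearing a 2-hydroxyethyl chain would begin to separate them, and a carboxylic acid in place of the methyl ester remains an open case at this position.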